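Methyl for Cyclopropyl: Expected Half-Life of Compound 3

The compounds below may be only part of what the source reports. "The series", "measured", "known", "first", "only" and "open" are said of these compounds alone.

In an ADME assay on the whole organism (Macaca fascicularis) for metabolic stability (on this read-out higher numbers stand for a longer-lived compound and lower numbers for a shorter-lived compound), compound 2 `Cc1ccc(-c2nc(=O)o[nH]2)c(-c2ccc([C@@H](C)N(CC3CC3)c3nc(C(=O)NS(=O)(=O)C4CC4)c(C4CC4)s3)cc2)c1` gives 3.1 h, while compound 1 `CCc1sc(N(CC2CC2)[C@H](C)c2ccc(-c3cc(C)ccc3-c3nc(=O)o[nH]3)cc2)nc1C(=O)NS(=O)(=O)C1CC1` gives 3 h, and the two numbers sit within the scatter of each other. Compound 3 `Cc1ccc(-c2nc(=O)o[nH]2)c(-c2ccc([C@@H](C)N(CC3CC3)c3nc(C(=O)NS(=O)(=O)C4CC4)c(C)s3)cc2)c1` differs from compound 2 by methyl in place of cyclopropyl on an aromatic carbon. Among the measured compounds shown here, the one step already measured at this aromatic carbon, a 1.0-fold higher number from compound 1 to compound 2 (0.01 log units; within the scatter), stayed within the scatter. A further change of the group on the same aromatic carbon is therefore expected to produce nothing beyond the scatter, and the expected step is a 1.0-fold lower number from compound 2 to compound 3 (0.01 log units; within the scatter). Compound 3 is estimated to give 3 h, within a range of 1.5 h to 6 h.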

Compound 3, half-life: 2.1 h
Estimate against measurement, compound 3: 1.4-fold (0.15 log units) above, within the range that was stated.
By their numbers in this assay, from the lowest: compounds 3, 1 and 2 (each within the scatter of the next).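

In this assay, methyl in place of cyclopropyl on the aromatic carbon next to the ring sulfur gives a 1.5-fold lower number from compound 2 to compound 3 (0.17 log units; within the scatter), and methyl in place of ethyl at the same carbon gives a 1.4-fold lower number from compound 1 to compound 3 (0.15 log units; within the scatter). Methyl, ethyl and cyclopropyl have therefore all been compared directly here, and no step among them lies beyond the scatter. Nothing available gives a reason for these numbers. As far as these compounds go, whether an amine, a carboxylic acid or a longer chain on this carbon would move the half-life beyond the scatter remains open.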